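From 3-methoxyphenyl to 2,4-dichlorophenyl on a shared core

The source may report more compounds than this note shows. Statements on the series, on what has been measured and on what is new or still open speak of the compounds shown alone.

Compound 1 `O=C1C(=Cc2ccc(Br)cc2)C(=O)N(c2ccc(Cl)cc2)N1c1ccc(Cl)cc1` gives 30400 nM
Compound 2 `COc1cccc(C=C2C(=O)N(c3ccc(Cl)cc3)N(c3ccc(Cl)cc3)C2=O)c1` gives 18100 nM

In a functional assay on MCF7 cells (Homo sapiens) for cytotoxicity, read by MTT assay, with a stated time of 72 h (on this read-out lower numbers stand for stronger inhibition and higher numbers for weaker inhibition), compound 2 gives 18100 nM and stands level with compound 1 at 30400 nM on the two numbers available. Compound 3 `O=C1C(=Cc2ccc(Cl)cc2Cl)C(=O)N(c2ccc(Cl)cc2)N1c1ccc(Cl)cc1` keeps the shared core and differs from compound 2 in one group: 2,4-dichlorophenyl in place of 3-methoxyphenyl on a double-bonded chain carbon bound to a double-bonded ring carbon. This puts 2,4-dichlorophenyl in place of 3-methoxyphenyl on a double-bonded chain carbon bound to a double-bonded ring carbon. Among the measured compounds shown here, only one measured step bears on this change: a 1.7-fold lower number from compound 1 to compound 2 (0.23 log units; within the scatter) with 3-methoxyphenyl in place of 4-bromophenyl at that same place. On the evidence of that one step, no step beyond the scatter is expected in this assay in either direction. For the measured compounds named here, this is thin support, as no measured compound carries 2,4-dichlorophenyl. The expected size of the change is a 1.1-fold higher number from compound 2 to compound 3 (0.04 log units; within the scatter) as estimated from these numbers. For compound 3 the estimated value is 20000 nM with an expected range from 8000 nM to 50000 nM.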

Compound 3, half-maximal inhibitory concentration: > 128000 nM
Compound 3 gave a limit, no number; the forecaster's own chance of this, stated with the estimate: 10%; middle value at least 6.4-fold (0.80 log units) away from the limit.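

In this assay, the result for compound 3 is a limit of the assay and not a number: the limit of > 128000 nM in this assay, at which 1 of the 3 values shown sits.

Even so, the change can be read as a step, since 2,4-dichlorophenyl in place of 3-methoxyphenyl gives an at least 7.0-fold higher number from compound 2 to compound 3 (0.84 log units; beyond the scatter), and 2,4-dichlorophenyl in place of 4-bromophenyl gives an at least 4.2-fold higher number from compound 1 to compound 3 (0.62 log units; beyond the scatter). The only earlier step at this place, a 1.7-fold lower number from compound 1 to compound 2 (0.23 log units; within the scatter), had shown no difference between the two groups, whereas compound 3 shows that the group on the double-bonded chain carbon can move the number beyond the scatter, towards weaker inhibition, on an unchanged core.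

The three compounds leave open whether the two chlorines must be present together for this loss, as a phenyl ring carrying one chlorine would begin to tell, and how far the true value of compound 3 lies past its limit. They also leave open whether a group of another kind at this place, such as an amine or a carboxylic acid on the phenyl ring, would give a lower number than those of compound 1 and compound 2.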